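Swapping the aryl ring of a hydrazone for a chloronitrophenyl

A few compounds are considered here, and "the series" means these few. Any claim that something is new, unique, unknown or untested is made for them only; others in the source may bear on it.

Measured so far:
Compound 1, `CSc1nn(-c2ccccc2)c2ncnc(N/N=C/c3ccc(F)cc3)c12`, gives 7.5 nM in a functional assay on MCF7 cells (Homo sapiens) for inhibition, read by sulforhodamine B assay, with a stated time of 48 h; a higher number here means a weaker inhibitor, a lower number a stronger inhibitor.
Compound 2, `CSc1nn(-c2ccccc2)c2ncnc(N/N=C/c3ccc(O)cc3)c12`, gives 10.3 nM in this assay.

For the measured compounds named here, compound 2 holds the higher of the two numbers, but the only measured step, a 1.4-fold higher number from compound 1 to compound 2 (0.14 log units; within the scatter), lies within the scatter, so the two compounds are not separated on these data. Compound 3, `CSc1nn(-c2ccccc2)c2ncnc(N/N=C/c3ccc([N+](=O)[O-])cc3Cl)c12`, is not yet measured. It differs from compound 2 by 2-chloro-4-nitrophenyl in place of 4-hydroxyphenyl on a carbon with a double bond to nitrogen. The step from compound 1 to compound 2 is the only one that touches this aryl ring, and it shows that exchanging the group on that ring left the number within the scatter. Going by the values given here, no measured step covers a chlorine or a nitro group on this ring, so the size of the change is uncertain, and no move beyond the scatter is expected. Compound 3 is therefore estimated at 12 nM, in a range from 4 nM to 40 nM, a step of a 1.2-fold higher number from compound 2 to compound 3 (0.07 log units; within the scatter).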

Compound 3, half-maximal inhibitory concentration: 15.7 nM
Compound 3: middle estimate off by 1.3-fold (0.12 log units), on the low side, within the range that was stated.
By their numbers in this assay, from the lowest: compounds 1, 2 and 3 (each within the scatter of the next, the first and the last beyond it).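

In this assay the exchange of 4-hydroxyphenyl for 2-chloro-4-nitrophenyl gives a 1.5-fold higher number from compound 2 to compound 3 (0.18 log units; within the scatter) and so does not separate the two groups at this position, although the entering group has more heavy atoms and no hydrogen-bond donor. Set against 4-fluorophenyl, the same group gives a 2.1-fold higher number from compound 1 to compound 3 (0.32 log units; beyond the scatter) as the first step at this position to pass the scatter, and a modest one. Nothing shown accounts for that step.

On these data alone, the chlorine and the nitro group enter together, so the share of each in the step stays open. Also open, as far as these compounds go, is how the number responds at this position to an amine or a carboxylic acid on the aryl ring, or to a longer chain in place of that ring.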